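The compounds below may be only part of what the source reports. "The series", "measured", "known", "first", "only" and "open" are said of these compounds alone.

Compound 3 `O=C(NCc1ccc(CNS(=O)(=O)c2ccccc2F)cc1)c1ccc(F)cc1` stands lowest of the three compounds in an assay on MDA-MB-231 cells for binding affinity to C-X-C chemokine receptor type 4 (Homo sapiens), read by fluorescence and microscopy, with stated times of 10 min and 30 min (a lower number here means that less compound is needed, a higher number that more compound is needed for the effect), at 10 nM. Compound 1 `O=C(NCc1ccc(CNS(=O)(=O)c2ccc(-c3ccc(F)cc3)cc2)cc1)c1ccc(F)cc1` gives 100 nM in this assay, and compound 2 `O=C(NCc1ccc(CNS(=O)(=O)c2cccc3ccccc23)cc1)c1ccc(F)cc1` gives 1000 nM. Within the data shown here, the one measured step at the sulfonyl sulfur is a 100-fold lower number from compound 2 to compound 3 (2.00 log units; beyond the scatter). Compound 4 `O=C(NCc1ccc(CNS(=O)(=O)c2cccc(F)c2)cc1)c1ccc(F)cc1` differs from compound 3 only there: 3-fluorophenyl in place of 2-fluorophenyl on a sulfonyl sulfur. Among the measured compounds shown here, no measured step moves the fluorine within a phenyl on that sulfur, so a 100-fold lower number from compound 2 to compound 3 (2.00 log units; beyond the scatter) bears only loosely on it; the two values of compound 1 and compound 3 show that other groups on this sulfur gave higher numbers. A small rise is expected, with the step from compound 3 to compound 4 estimated as a 3.0-fold higher number from compound 3 to compound 4 (0.48 log units; beyond the scatter). Compound 4 is expected to give 30 nM, between 10 nM and 100 nM.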

Compound 4, effective concentration (reported as EC, without a stated level of effect): 1000 nM
For compound 4 the middle estimate is 33-fold (1.52 log units) below the measured one, and the stated range ends below it.
By their numbers in this assay, from the lowest: compound 3; then compound 1; then compounds 2 and 4 (each within the scatter of the next).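

In this assay, moving the fluorine on the phenyl at the sulfonyl sulfur, with the atoms unchanged, gives a 100-fold higher number from compound 3 to compound 4 (2.00 log units; beyond the scatter) and so counts for as much as the earlier change of the whole group. Replacing naphthalen-1-yl with 3-fluorophenyl gives no change at the digits printed from compound 2 to compound 4 (within the scatter) and keeps none of the gain seen with 2-fluorophenyl. The low number therefore goes with the 2-fluorophenyl here, not with any fluorophenyl. As far as these compounds go, whether chlorine or a methoxy group in place of the fluorine of the 2-fluorophenyl would keep that low number remains open. Nothing available explains why the fluorine's place matters so much.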